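The compounds below may be only part of what the source reports. "The series", "measured", "known", "first", "only" and "open" are said of these compounds alone.

The shared core on its own is compound 3 `O=C1C=CC(=O)c2ncncc21`; in a functional assay on MIA PaCa-2 cells (Homo sapiens) for cytotoxicity, read by MTT assay, with a stated time of 72 h (a lower number here means a stronger inhibitor, a higher number a weaker inhibitor), compound 3 gives 9400 nM. Two anilino-bearing analogues are compound 1 `COc1cc(NC2=CC(=O)c3ncncc3C2=O)cc(OC)c1OC` and compound 2 `COC(=O)c1ccc(NC2=CC(=O)c3ncncc3C2=O)cc1`. In this assay compound 1 gives 1500 nM and compound 2 gives 2200 nM. Compound 2 therefore stands second highest of the three numbers: its gap to compound 1 lies within the scatter, while its gap to compound 3 lies beyond it. The next compound, compound 4 `NC(=O)c1ccc(NC2=CC(=O)c3ncncc3C2=O)cc1`, differs from compound 2 in one place: amino in place of methoxy on a carbonyl carbon, that is, methoxycarbonyl to carbamoyl. Within the data shown here, no measured pair shows this change, so no step beyond the scatter is expected. For compound 4 the estimated step is a 1.1-fold higher number from compound 2 to compound 4 (0.06 log units; within the scatter), giving an expected value of 2500 nM, between 900 nM and 7000 nM.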

Compound 4, half-maximal inhibitory concentration: 8000 nM
Beside the measured number, compound 4's estimate is 3.2-fold (0.51 log units) below it; the whole stated range lies below it.
By their numbers in this assay, from the lowest: compounds 1 and 2 (each within the scatter of the next); then compounds 4 and 3 (each within the scatter of the next).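

In this assay the group on this carbonyl carbon proves to matter: replacing methoxy with amino brings a modest but real weakening (a 3.6-fold higher number from compound 2 to compound 4 (0.56 log units; beyond the scatter)). The methoxycarbonyl and carbamoyl forms are therefore not interchangeable at this position, at least on this anilino-bearing compound. Nothing available here explains the shift. The compounds shown leave open whether a carboxylic acid or a methylamino group on the same carbonyl carbon would give a number closer to compound 2 or to compound 4.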